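From 2-methylphenyl to 4-fluorobenzyl on a growth inhibitor

The source may hold more compounds than are shown below. What is called first, only, known or untested is meant among the compounds shown, and "the series" means these compounds.

Within the data shown here, in a functional assay on MDA-MB-231 cells (Homo sapiens) for inhibition, read by CCK-8 assay, with a stated time of 48 h (a higher number here means a weaker inhibitor of growth, a lower number a stronger inhibitor of growth), compound 1 `Cc1ccccc1Nc1nc(Nc2ccc(N3CCN(C)CC3)cn2)ncc1Cl` gives 7470 nM, the only actual number among the three compounds measured so far. Compound 2 `CCN1CCN(c2ccc(Nc3ncc(Cl)c(Nc4ccccc4C)n3)nc2)CC1` reaches only a limit of the assay, > 100000 nM. Compound 3 `Cc1ccccc1Nc1nc(Nc2ccc(N3CCCCC3)cn2)ncc1Cl` likewise gives only a limit, > 100000 nM.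

Compound 4 `CN1CCN(c2ccc(Nc3ncc(Cl)c(NCc4ccc(F)cc4)n3)nc2)CC1` has not yet been measured. It keeps the core of compound 1 and places 4-fluorobenzyl in place of 2-methylphenyl on a nitrogen on an aromatic ring.

Among the measured compounds shown here, no measured step changes this group, so the evidence is indirect. The two readable steps both alter the piperazine end of compound 1. One is an at least 13-fold higher number from compound 1 to compound 2 (1.12 log units; beyond the scatter), and the other is an at least 13-fold higher number from compound 1 to compound 3 (1.12 log units; beyond the scatter). Both are large and both lead to a weaker result, so the measurable activity of compound 1 is shown to be easily lost, though only for changes elsewhere in the molecule. A moderate move towards a higher number is therefore expected, with wide uncertainty, and the estimated step is a 2.0-fold higher number from compound 1 to compound 4 (0.30 log units; within the scatter). For compound 4 the expected value is 15000 nM, within an estimated range of 4000 nM to 80000 nM.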

Compound 4, concentration for 50% growth inhibition: > 100000 nM
Compound 4 gave a limit, no number; the forecaster's own chance of this, stated with the estimate: 35%; middle value at least 6.6-fold (0.82 log units) from the limit.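

In this assay, among these compounds, placing 4-fluorobenzyl in place of 2-methylphenyl on a nitrogen on an aromatic ring gives an at least 13-fold higher number from compound 1 to compound 4 (1.12 log units; beyond the scatter), the first measured step at this position. The readable activity of compound 1 is therefore lost with a change at this nitrogen, just as it was with the two changes at the piperazine end, so among the four compounds shown, only the exact combination in compound 1 gives a number. The value for compound 4 is a limit and not a number, so this step gives only a minimum size, the step between compound 2 and compound 3 cannot be read, and the series offers little room for comparison: the limit of > 100000 nM in this assay, at which 3 of the 4 values shown sit.

The compounds shown cannot separate the loss of the 2-methylphenyl group from the arrival of the fluorine or of the benzyl form, and a plain benzyl, a 4-fluorophenyl or an unsubstituted phenyl on this nitrogen would help to tell these apart. They also leave open whether any group at this position can give a lower number than compound 1, which would show whether this nitrogen substituent can be improved at all.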